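The source may report more compounds than this note shows. Statements on the series, on what has been measured and on what is new or still open speak of the compounds shown alone.

In an ADME assay on BJ cells (Homo sapiens) for cytotoxicity, with a stated time of 72 h (a lower number here means that less compound is needed, a higher number that more compound is needed for the effect), compound 2 `COc1ccc(-c2nc3ccccc3s2)cc1NC(=O)c1cc([N+](=O)[O-])ccc1Cl` gives > 25000 nM, a limit of the assay and not a number. Compound 3 `COc1ccc(-c2nc3ccccc3s2)cc1NC(=O)c1cc([N+](=O)[O-])c(N2CCC(C(=O)O)CC2)cc1Cl` is built from it by one change, (4-carboxypiperidin-1-yl in place of hydrogen on an aromatic carbon), with 4-carboxypiperidin-1-yl in place of hydrogen on an aromatic carbon, ortho to a nitro group. Compound 1 `Cc1ccc(-c2nc3ccccc3s2)cc1NC(=O)c1cc([N+](=O)[O-])c(N2CCC(C(=O)O)CC2)cc1Cl` already carries this group and gives > 25000 nM, again a limit. Among the measured compounds shown here, no measured step isolates the change, so the expectation is for no step beyond the scatter, in either direction. The expected step that the limit leaves unreadable from compound 2 to compound 3 is therefore small. Compound 3 is estimated at 30000 nM, within a range of 15000 nM to 60000 nM.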

Compound 3, half-maximal effective concentration: > 25000 nM
Compound 3 gave a limit, no number; the forecaster's own chance of this, stated with the estimate: 90%; the middle value is on the limit's open side.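

No step can be read from compound 2 to compound 3 or from compound 1 to compound 3, because all three compounds give only a limit: the limit of > 25000 nM in this assay, at which 3 of the 3 values shown sit.

Going by these compounds, whether adding 4-carboxypiperidin-1-yl or replacing methyl with methoxy shifts the read-out in either direction remains open.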